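Swapping the amide-bearing ring on compound 1's piperazine

The compounds below may be only part of what the source reports. "The series", "measured", "known", "first", "only" and "open" are said of these compounds alone.

Compound 1, `Cc1nc(-c2ccccc2)c(C(=O)N2CCN(c3cccc(C(N)=O)c3)CC2)o1`, is tested in a functional assay on HL-60 cells (Homo sapiens) for inhibition, read by MTT assay, with a stated time of 72 h (a lower number here means a stronger inhibitor, a higher number a weaker inhibitor), where it gives 71 nM. Among the compounds with values here, the only other compound measured here, compound 2, `COc1cc(OC)cc(N2CCN(C(=O)c3onc(C)c3-c3ccc(F)cc3)CC2)c1`, shows 475 nM in this assay, so compound 1 stands with the lower of the two numbers, and the gap between them lies beyond the usual scatter. Compound 2 differs from compound 1 in more than one place, so its value can only serve as a rough comparison.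

Compound 3, `Cc1nc(-c2ccccc2)c(C(=O)N2CCN(c3c(C)cccc3C)CC2)o1`, has not yet been measured. It differs from compound 1 in one place: 2,6-dimethylphenyl in place of 3-carbamoylphenyl on an amine nitrogen in a ring. The group that leaves carries one hydrogen-bond donor and one hydrogen-bond acceptor, while the group that enters carries none.

Within the data shown here, with no single-point step measured, the direction is uncertain. The expectation is a step toward a weaker inhibitor of a 3.5-fold higher number from compound 1 to compound 3 (0.55 log units; beyond the scatter), larger than the scatter, because compound 2, which also lacks donors on its ring attached to the same ring nitrogen, gives 475 nM. Compound 3 is therefore estimated at 250 nM in this assay, with a plausible range from 60 nM to 1000 nM.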

Compound 3, half-maximal inhibitory concentration: 146 nM
Compound 3: the middle estimate sits 1.7-fold (0.23 log units) above what was measured, within the range that was stated.
By their numbers in this assay, from the lowest: compound 1; then compound 3; then compound 2.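

Putting 2,6-dimethylphenyl in place of 3-carbamoylphenyl on the amine nitrogen in the ring costs only a modest amount in this assay, with a 2.1-fold higher number from compound 1 to compound 3 (0.31 log units; beyond the scatter) as the step, so this position accepts a ring with no hydrogen-bond donor or acceptor, and compound 3 still gives 146 nM as an inhibitor. The carbamoyl group leaves and two methyl groups arrive in the same change, so the step cannot be divided between the loss of the one and the gain of the others. Nothing measured here explains why the number moves.

Still open, from the compounds shown here alone, is whether the carbamoyl group itself accounts for the lower number of compound 1 or whether the two methyl groups raise the number of compound 3, a question that a plain unsubstituted phenyl ring at this position would help to settle. Going by these compounds, it also remains unknown how a ring bearing a carboxylic acid, an amine or a nitrile would compare with these two groups on the same core.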